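The compounds below may be only part of what the source reports. "The series", "measured", "known", "first", "only" and "open" are said of these compounds alone.

In a functional assay on MDA-MB-436 cells (Homo sapiens) for antiproliferative activity, read by MTT assay, with a stated time of 48 h (a lower number here means a stronger inhibitor, a higher number a weaker inhibitor), the measured compounds are:

- compound 1 `C=CS(=O)(=O)N1CCN(c2ncnc3sc(-c4ccnc(Cl)c4)cc23)CC1` with 30100 nM as its value
- compound 2 `CN1CCN(c2ccc(-c3cc4c(N5CCN(S(=O)(=O)N6CCCCC6)CC5)ncnc4s3)cc2)CC1` with 7570 nM as its value

Compound 2 has the lower number of the two, and its gap to compound 1 lies beyond the scatter. Compound 3 `CN1CCN(c2ccc(-c3cc4c(N5CCN(C(=O)Nc6ccccc6F)CC5)ncnc4s3)cc2)CC1` has not yet been measured in this assay and differs from compound 2 in one place, with (2-fluorophenyl)carbamoyl in place of (piperidin-1-yl)sulfonyl on an amine nitrogen in a ring. Among the compounds with values here, no measured pair shows what a change at this place does, so the expectation rests on compound 2 at 7570 nM alone and stays loose. A small move toward a lower number is expected, probably not beyond the scatter. The estimate amounts to a 1.3-fold lower number from compound 2 to compound 3 (0.10 log units; within the scatter) as the expected step. For compound 3 the estimated value is 6000 nM within an expected range from 1500 nM to 24000 nM in this readout.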

Compound 3, half-maximal inhibitory concentration: 14300 nM
Estimate against measurement, compound 3: 2.4-fold (0.38 log units) below, and the stated range covers the measured number.
By their numbers in this assay, from the lowest: compounds 2 and 3 (each within the scatter of the next); then compound 1.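

Within the data shown here, the step of a 1.9-fold higher number from compound 2 to compound 3 (0.28 log units; within the scatter) in this assay is the first reading of a change on this amine nitrogen in a ring. It shows that (2-fluorophenyl)carbamoyl, with its aromatic ring and hydrogen-bond donor, and (piperidin-1-yl)sulfonyl, with its non-aromatic ring and no such donor, cannot be told apart at this position in this readout. No measured evidence is available to explain this outcome.

The compounds shown leave open whether a smaller group on this nitrogen, such as acetyl or methyl, or a group carrying a carboxylic acid or an amine, would give a different number. They also leave open what the fluorine contributes, since a phenylcarbamoyl group without it does not appear among them.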